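This account rests on a few compounds, and the source may have more. Where it says the series, first, only, none or still open, it means among the compounds named here.

In a functional assay for inhibition (on this read-out higher numbers stand for weaker inhibition and lower numbers for stronger inhibition), compound 3 `CCCCCCOc1ccc2c(=O)cc(-c3cc(C(C)(C)C)c(O)c(C(C)(C)C)c3)oc2c1` gives 5000 nM, the highest number among the three compounds measured, though the gap to each of the others lies within the scatter: compound 1 `CC(C)(C)c1cc(-c2cc(=O)c3ccc(OCC(=O)N4CCN(Cc5ccccc5)CC4)cc3o2)cc(C(C)(C)C)c1O` gives 3000 nM, and compound 2 `CCOC(=O)CCCCOc1ccc2c(=O)cc(-c3cc(C(C)(C)C)c(O)c(C(C)(C)C)c3)oc2c1` gives 3000 nM. Among the measured compounds shown here, the one step that can be traced between measured compounds, a 1.7-fold higher number from compound 2 to compound 3 (0.22 log units; within the scatter), concerns the far end of the chain and did not move the read-out beyond the scatter.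

Compound 4 `CC(C)(C)c1cc(-c2cc(=O)c3ccc(OCC(=O)N4CCCCC4)cc3o2)cc(C(C)(C)C)c1O` differs from compound 3 closer to the ring: (piperidin-1-yl)carbonyl in place of pentyl on a saturated chain carbon bound to an oxygen on an aromatic ring. For the measured compounds named here, no measured step covers this kind of change. Compound 1, which also carries a carbonyl group joined to a nitrogen-containing ring on the same chain position, and compound 3 show values within the scatter of each other, and all three numbers sit close together. The expectation for this assay is therefore a step of a 1.4-fold lower number from compound 3 to compound 4 (0.15 log units; within the scatter), that is, no change beyond the scatter. Compound 4 is expected to give 3500 nM, within a range of 1500 nM to 8000 nM.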

Compound 4, half-maximal inhibitory concentration: 3000 nM
Compound 4: middle estimate off by 1.2-fold (0.07 log units), on the high side, within the range that was stated.
By their numbers in this assay, from the lowest: compounds 1, 2, 4 and 3 (each within the scatter of the next).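

In this assay, placing (piperidin-1-yl)carbonyl on a saturated chain carbon bound to an oxygen on an aromatic ring, in place of pentyl, gives a 1.7-fold lower number from compound 3 to compound 4 (0.22 log units; within the scatter) and so shows that a ring and a hydrogen-bond acceptor can enter here without moving the read-out beyond the scatter. The same group in place of 3-(ethoxycarbonyl)propyl gives no change at the digits printed from compound 2 to compound 4 (within the scatter) and thus adds a second, different chain that the read-out does not separate from it. No measurement offered here explains why these groups give such similar numbers.

Still open, from the compounds shown here alone, is whether any group at this place can move the number beyond the scatter. A carboxylic acid or a dimethylamino group at the end of the chain, or a much longer chain, would test this.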